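This account rests on a few compounds, and the source may have more. Where it says the series, first, only, none or still open, it means among the compounds named here.

Measured in a functional assay (Mus musculus) for inhibition, with a stated time of 5 days; a higher number here means a weaker inhibitor, a lower number a stronger inhibitor:
- Compound 1 `CCOC(=O)/C=C/c1cn(-c2ccc(O)cc2)nc1-c1cccc(O)c1`: 14000 nM
- Compound 2 `O=Cc1cn(-c2ccc(O)cc2)nc1-c1cccc(O)c1`: 42000 nM
- Compound 3 `O=Cc1cn(-c2ccc(O)cc2)nc1-c1ccccc1`: > 100000 nM, a limit of the assay

Of the two true numbers, compound 2 has the higher. The nearest value belongs to compound 1, and the change of group gave a 3.0-fold higher number from compound 1 to compound 2 (0.48 log units; beyond the scatter).

Compound 4 `O=Cc1cn(-c2ccc(O)cc2)nc1-c1cc(O)ccc1O` carries one extra hydroxy, ortho to a large group and para to a hydroxy group: hydroxy in place of hydrogen on an aromatic carbon. The closest evidence is the loss of a different hydroxy, which gave an at least 2.3-fold higher number from compound 2 to compound 3 (0.37 log units; beyond the scatter) and reached (the limit of > 100000 nM in this assay, at which 1 of the 3 values shown sits). That step suggests, though only loosely for a new place, that another hydroxy may give a modestly stronger inhibitor.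

The expected change is a 2.1-fold lower number from compound 2 to compound 4 (0.32 log units; beyond the scatter).

For compound 4 the estimated value is 20000 nM, with an expected range of 6000 nM to 70000 nM.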

Compound 4, half-maximal inhibitory concentration: 43000 nM
Beside the measured number, compound 4's estimate is 2.2-fold (0.33 log units) below it; low and high end bracket the measured number.
By their numbers in this assay, from the lowest: compound 1; then compounds 2 and 4 (each within the scatter of the next). At a limit, above all of these: compound 3.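

In this assay, a further hydroxy, ortho to a large group and para to a hydroxy group, gives a 1.0-fold higher number from compound 2 to compound 4 (0.01 log units; within the scatter). At this place, then, the added hydroxy shows no gain in inhibition, so the earlier hydroxy step does not carry over to every position on this ring. The comparison behind that earlier step ends in a limit for compound 3: the limit of > 100000 nM in this assay, at which 1 of the 4 values shown sits.

Going by these compounds, whether an amine or a methoxy group at this place would also sit within the scatter of compound 2 stays open. Also open, on these data alone, is whether this extra hydroxy would matter on compound 1, with its 2-(ethoxycarbonyl)ethenyl group.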